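The source may hold more compounds than are shown below. What is called first, only, known or untested is meant among the compounds shown, and "the series" means these compounds.

Among the measured compounds shown here, compound 2, `Cc1ccc(C)n1-c1ccc2c(c1)C(n1ccccc1=O)=CC(C)(C)O2`, is one of two compounds measured so far in a functional assay (aorta) with Rattus norvegicus as the target; a higher number here means a more potent compound, by a factor of ten per unit of this negative logarithm, a lower number a less potent compound. In this assay compound 2 gives 7.27, the higher of the two numbers. For the measured compounds named here, its only neighbour is compound 1, `COc1ccc2c(c1)C(n1ccccc1=O)=CC(C)(C)O2`, in which a methoxy sits in place of the 2,5-dimethyl-1H-pyrrol-1-yl; in this assay compound 1 gives 6.55. Going by the values given here, the one step seen so far is a number 0.72 log units higher from compound 1 to compound 2 (beyond the scatter), so the group at this position clearly matters.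

Compound 3, `CC1(C)C=C(n2ccccc2=O)c2cc(C#N)ccc2O1`, has not yet been measured. It differs from compound 2 as follows: cyano in place of 2,5-dimethyl-1H-pyrrol-1-yl on an aromatic carbon. Among the compounds with values here, no measured step covers an exchange of the 2,5-dimethyl-1H-pyrrol-1-yl for a cyano, so the one step from compound 1 to compound 2 shows only that changing the group at this aromatic carbon can move the number beyond the scatter, not in which direction a cyano would move it. For compound 3 the step is therefore expected to be small, a number 0.13 log units higher from compound 2 to compound 3 (within the scatter), with wide uncertainty. The estimate for compound 3 in this assay is 7.4, within a range from 6.6 to 8.2.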

Compound 3, logarithm of the reciprocal of the active concentration, log(1/C): 7.67
Compound 3: the middle estimate sits 0.27 log units below what was measured; the measured number falls inside the stated range.
By their numbers in this assay, from the lowest: compound 1; then compound 2; then compound 3.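

In this assay, cyano in place of 2,5-dimethyl-1H-pyrrol-1-yl gives a number 0.40 log units higher from compound 2 to compound 3 (beyond the scatter), which shows that a five-membered aromatic ring at this aromatic carbon is not needed for a high number, since a group with no ring and fewer heavy atoms does better. Compared with methoxy, the same cyano gives a number 1.12 log units higher from compound 1 to compound 3 (beyond the scatter), a large step and the widest gap among these compounds, so the choice of group at this single position spans more than the first pair suggested, and the order now runs from methoxy through 2,5-dimethyl-1H-pyrrol-1-yl to cyano. Nothing available explains this order.

Only three groups are shown at this position, so it remains open whether a chlorine atom, an amine, a carboxylic acid or a nitro group would give a number above or below that of cyano. Going by these compounds, all three compounds also share the rest of their structure, and whether the same order would hold after a change elsewhere in the shared core remains open too.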